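Heteroaryl Swap on the Amide Nitrogen of a Phenoxyacetamide

The source may hold more compounds than are shown below. What is called first, only, known or untested is meant among the compounds shown, and "the series" means these compounds.

Compound 1 `Cc1ccc(OCC(=O)N(Cc2cccs2)C2CCCCC2)cc1`: 40000 nM
Compound 2 `CON(Cc1cccs1)C(=O)COc1ccc(C)cc1`: 10 nM
Compound 3 `Cc1ccc(OCC(=O)N(Cc2cccs2)c2ccnn2C)cc1`: 422 nM

The three measured compounds share one core and differ only in the group on the amide-type nitrogen. In an assay on HEK293 cells for agonist activity at transient receptor potential cation channel subfamily M member 8 (Homo sapiens), read by fluorescence and calcium flux, with a stated time of 15 min (on this read-out lower numbers stand for an effect already at smaller amounts and higher numbers for an effect only at larger amounts of compound), compound 3 gives 422 nM, the second highest of the three numbers; the steps of a 42-fold higher number from compound 2 to compound 3 (1.63 log units; beyond the scatter) and a 95-fold lower number from compound 1 to compound 3 (1.98 log units; beyond the scatter) were both large. Compound 4 `Cc1ccc(OCC(=O)N(Cc2cccs2)c2nccs2)cc1` carries 1,3-thiazol-2-yl in place of 1-methyl-1H-pyrazol-5-yl on an amide-type nitrogen. Within the data shown here, no measured step exchanges one five-membered aromatic ring for another; the steps of a 4000-fold lower number from compound 1 to compound 2 (3.60 log units; beyond the scatter) and a 95-fold lower number from compound 1 to compound 3 (1.98 log units; beyond the scatter) show that this position moves the read-out strongly, but both start from cyclohexyl. Compound 3 already holds a five-membered aromatic ring with 2 hetero atoms there, so the step in this assay is expected to be small, a 1.4-fold lower number from compound 3 to compound 4 (0.15 log units; within the scatter). Compound 4 is estimated at 300 nM, within 60 nM to 1500 nM.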

Compound 4, half-maximal effective concentration: 2240 nM
Compound 4: the middle estimate sits 7.5-fold (0.87 log units) below what was measured, and the stated range ends below it.
By their numbers in this assay, from the lowest: compound 2; then compound 3; then compound 4; then compound 1.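

In this assay the exchange of one five-membered aromatic ring with 2 hetero atoms for another does change the read-out, with a 5.3-fold higher number from compound 3 to compound 4 (0.72 log units; beyond the scatter) at unchanged counts of hydrogen-bond donors and acceptors. The identity of the ring therefore counts at this amide-type nitrogen, and 1,3-thiazol-2-yl stands apart from the other groups, with an 18-fold lower number from compound 1 to compound 4 (1.25 log units; beyond the scatter) on one side and a 220-fold higher number from compound 2 to compound 4 (2.35 log units; beyond the scatter) on the other. No available evidence accounts for the gap between the two rings. Where phenyl or pyridin-2-yl would fall remains open, as does whether ethoxy or hydroxy would match methoxy.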